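This account rests on a few compounds, and the source may have more. Where it says the series, first, only, none or still open, it means among the compounds named here.

In an assay on MDA-MB-231 cells for displacement of a labelled ligand from C-X-C chemokine receptor type 4 (Homo sapiens), read by fluorescence and microscopy, with stated times of 10 min and 30 min (a higher number here means that more compound is needed for the effect, a lower number that less compound is needed), three closely related compounds have been measured. Compound 2 `COc1ccccc1C(=O)NCc1ccc(CNS(=O)(=O)c2ccc([N+](=O)[O-])cc2)cc1` gives 100 nM. Compound 1 `COc1ccccc1C(=O)NCc1ccc(CNS(=O)(=O)c2cccc(F)c2)cc1` gives 1000 nM, and compound 3 `Cc1ccccc1C(=O)NCc1ccc(CNS(=O)(=O)c2ccc([N+](=O)[O-])cc2)cc1` gives 100 nM. Compound 3 differs from compound 2 in that (methyl in place of methoxy on an aromatic carbon), and the outcome was no change at the digits printed from compound 2 to compound 3 (within the scatter). Compound 1 differs from compound 2 in that (3-fluorophenyl in place of 4-nitrophenyl on a sulfonyl sulfur), and that change produced a 10-fold higher number from compound 2 to compound 1 (1.00 log units; beyond the scatter).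

Compound 4 `Cc1ccccc1C(=O)NCc1ccc(CNS(=O)(=O)c2cccc(F)c2)cc1` has not yet been measured in this assay. It carries the core of compound 3 and differs from compound 3 in that (3-fluorophenyl in place of 4-nitrophenyl on a sulfonyl sulfur). Going by the values given here, this is the same change as the one that separates compound 2 from compound 1, made at the same place with the same neighbouring atoms. Among the compounds with values here, the cores of compound 2 and compound 3 differ in the way already described, and that difference left the two numbers level, so there is nothing among the measured compounds to suggest that the second occurrence of the change should behave differently from the first. The expected step is therefore a 10-fold higher number from compound 3 to compound 4 (1.00 log units; beyond the scatter), because a 10-fold higher number from compound 2 to compound 1 (1.00 log units; beyond the scatter) was observed for the same change and, level with compound 2, compound 3 gives 100 nM. On this basis compound 4 is expected to give about 1000 nM in this assay, most plausibly somewhere between 400 nM and 2500 nM.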

Compound 4, effective concentration (reported as EC, without a stated level of effect): 100 nM
For compound 4 the middle estimate is 10-fold (1.00 log units) above the measured one; the measured number lies below the stated range.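

In this assay, 3-fluorophenyl in place of 4-nitrophenyl on a sulfonyl sulfur gave no change at the digits printed from compound 3 to compound 4 (within the scatter), so the change did not carry over unaltered from the core of compound 2 to the core of compound 3: the same change on two cores in this assay, a 10-fold higher number (1.00 log units; beyond the scatter) from compound 2 to compound 1 and no change at the digits printed (within the scatter) from compound 3 to compound 4, 10-fold (1.00 log units) apart, beyond the scatter of two such steps Read the other way round, methyl in place of methoxy on an aromatic carbon gave a 10-fold lower number from compound 1 to compound 4 (1.00 log units; beyond the scatter), so the outcome of that change also differed with the group on the sulfonyl sulfur: the same change on two cores in this assay, no change at the digits printed (within the scatter) from compound 2 to compound 3 and a 10-fold lower number (1.00 log units; beyond the scatter) from compound 1 to compound 4, 10-fold (1.00 log units) apart, beyond the scatter of two such steps Within these four compounds the two changes therefore do not add up independently, but a single square of compounds does not show why, nor whether the same dependence holds anywhere else in the series.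

The compounds shown leave open whether this behaviour is tied to methyl and methoxy or would also appear with an ethyl group or a chlorine atom on that aromatic carbon. They also leave open whether a plain phenyl or a phenyl carrying a nitrile on the sulfonyl sulfur would follow the 4-nitrophenyl compounds or the 3-fluorophenyl compounds on each of the two cores.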